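Aryl amide replacement and cytotoxicity in the shared series

The compounds below may be only part of what the source reports. "The series", "measured", "known", "first", "only" and "open" are said of these compounds alone.

Compound 1 `CSc1cccc(NC(=O)C2CCCN(C(=O)c3cc(C(F)(F)F)cc(C(F)(F)F)c3)C2)c1` shows no inhibition in an ADME assay on PC-3 cells (Homo sapiens) for cytotoxicity, read by WST assay, tested at 100 uM (a lower number here means less inhibition, a higher number more inhibition at the concentration tested (going by the name of the read-out)), giving 0%. Compound 3 `O=C(Nc1cccc(S(=O)(=O)N2CCCC2)c1)C1CCCN(C(=O)c2cc(C(F)(F)F)cc(C(F)(F)F)c2)C1` gives 0% in this assay, and compound 2 `O=C(Nc1cccc(OCCc2ccccn2)c1)C1CCCN(C(=O)c2cc(C(F)(F)F)cc(C(F)(F)F)c2)C1` gives 5%. The steps of a number 5 percentage points higher from compound 1 to compound 2 (within the scatter), no change at the digits printed from compound 1 to compound 3 (within the scatter) and a number 5 percentage points lower from compound 2 to compound 3 (within the scatter) all lie within the scatter, so compound 1 sits level with compound 3 at the low end of three flat numbers. Compound 4 `O=C(Nc1ccc(Cl)nc1)C1CCCN(C(=O)c2cc(C(F)(F)F)cc(C(F)(F)F)c2)C1` differs from compound 1 by 6-chloropyridin-3-yl in place of 3-(methylsulfanyl)phenyl on an amide-type nitrogen. Going by the values given here, no measured step touches the amide nitrogen; the three measured changes sit on the aromatic carbon and left the read-out flat. Compound 4 is therefore expected to move by a number 2 percentage points higher from compound 1 to compound 4 (within the scatter), nothing beyond the scatter. The estimate for compound 4 is 2%, with a range from 0% to 15%.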

Compound 4, a percentage reported as inhibition, at one concentration (the size of the read-out at that concentration, not a potency): 25%
Estimate against measurement, compound 4: 23 percentage points below; the whole stated range lies below it.
By their numbers in this assay, from the lowest: compounds 1, 3 and 2 (each within the scatter of the next); then compound 4.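

Exchanging the whole aryl group on the amide-type nitrogen moves this assay, whereas the changes on the aromatic carbon left it flat: 6-chloropyridin-3-yl in place of 3-(methylsulfanyl)phenyl gives a number 25 percentage points higher from compound 1 to compound 4 (beyond the scatter). Cytotoxicity in this series therefore responds to this change, although the single step does not separate the contributions of the ring nitrogen and the chlorine. Nothing available accounts for the rise.

Still open, as far as these compounds go, is which of those two features carries the step; a plain pyridinyl ring and a chlorophenyl group on the same nitrogen would divide them.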